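This account rests on a few compounds, and the source may have more. Where it says the series, first, only, none or still open, it means among the compounds named here.

In an ADME assay on BJ cells (Homo sapiens) for cytotoxicity, with a stated time of 72 h (a higher number here means that more compound is needed for the effect, a lower number that less compound is needed), compound 1 (`Cc1cc(NC(=O)Nc2ccc(C)c(Cl)c2)c2ccccc2n1`) reads > 25000 nM, which is a limit of the assay and not a number. Among the measured compounds shown here, compound 2 (`COC(=O)c1cccc(NC(=O)Nc2cc(C)nc3ccccc23)c1`) gives 21000 nM, the only true number so far. Next is compound 3 (`Cc1cc(NC(=O)Nc2cccc(OC(F)(F)F)c2)c2ccccc2n1`), with trifluoromethoxy in place of methoxycarbonyl on an aromatic carbon, meta to a large group: trifluoromethoxy in place of methoxycarbonyl on an aromatic carbon. For the measured compounds named here, no measured pair differs in one place alone, so the data give no direct guide to the size of this change. The expectation therefore rests on compound 2 at 21000 nM, and no shift beyond the scatter is anticipated in either direction. The expected change is a 1.1-fold lower number from compound 2 to compound 3 (0.02 log units; within the scatter). A limit reading for compound 3 would be no surprise. For compound 3 the estimated value is 20000 nM, within an expected range of 9000 nM to 40000 nM.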

Compound 3, half-maximal effective concentration: 25000 nM
Compound 3: the middle estimate sits 1.3-fold (0.10 log units) below what was measured; the measured number falls inside the stated range.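

Among the compounds shown here, this is the first step that can be read at a single place: in this assay, trifluoromethoxy in place of methoxycarbonyl on an aromatic carbon, meta to a large group, gives a 1.2-fold higher number from compound 2 to compound 3 (0.08 log units; within the scatter). The two groups differ in heavy atoms and in hydrogen-bond acceptors, yet this exchange at this position produces no step beyond the scatter. Compound 3 reads 25000 nM, which stands at the edge of the range reported as true numbers: the limit of > 25000 nM in this assay, at which 1 of the 3 values shown sits.

On these data alone, whether an amine, a carboxylic acid or a longer chain at this position would give a different number remains open. Only a group giving a number clearly lower than these would show that this position matters in this assay.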